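This account rests on a few compounds, and the source may have more. Where it says the series, first, only, none or still open, it means among the compounds named here.

Compound 1 `O=C(Nc1[nH]nc(-c2ccccn2)c1C1CC1)c1ccccc1F` gives > 100 mL.min-1.g-1
Compound 2 `O=C(Nc1cc(-c2ccccn2)n[nH]1)N1CCC(c2cccc(F)c2)CC1` gives 207 mL.min-1.g-1
Compound 3 `O=C(Nc1[nH]nc(-c2ccccn2)c1C1CC1)c1c(Cl)cccc1Cl` gives > 100 mL.min-1.g-1

Going by the values given here, in an ADME assay on liver (Mesocricetus auratus) for metabolic stability, using microsomes (on this read-out lower numbers stand for slow clearance and higher numbers for fast clearance), compound 2 gives 207 mL.min-1.g-1 as the only number among the values shown. Compound 1 gives > 100 mL.min-1.g-1 as a limit of the assay and not a number. Compound 3 gives > 100 mL.min-1.g-1 as a limit too. The evidence from the measured steps amounts to the limit of > 100 mL.min-1.g-1 in this assay, at which 2 of the 3 values shown sit, and little more. Among the compounds with values here, the one step between measured compounds is a step that the two limits leave unreadable from compound 1 to compound 3 and it concerns a different change, with no size to read.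

Compound 4 `O=C(Nc1cc(-c2ccccn2)n[nH]1)N1CCC(c2ccccc2)CC1` differs from compound 2 by hydrogen in place of fluoro on an aromatic carbon in the change from 3-fluorophenyl to phenyl, hydrogen in place of fluoro on an aromatic carbon. Within the data shown here, no measured step bears on this change, so no step beyond the scatter is expected in this assay in either direction. The expected step in this estimate is a 1.0-fold lower number from compound 2 to compound 4 (0.01 log units; within the scatter) and no more. Compound 4 is estimated at 200 mL.min-1.g-1 with an expected range from 100 mL.min-1.g-1 to 400 mL.min-1.g-1 if a number is returned.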

Compound 4, intrinsic clearance in microsomes: 216 mL.min-1.g-1
Estimate against measurement, compound 4: 1.1-fold (0.03 log units) below; the range from low to high includes it.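

Going by these compounds alone, the pair of compound 2 and compound 4 gives the first readable step in this assay: hydrogen in place of fluoro on an aromatic carbon, meta to a large group, gives a 1.0-fold higher number from compound 2 to compound 4 (0.02 log units; within the scatter). Within the data shown here, this shows that, on this pair, the change from 3-fluorophenyl to phenyl stays within the scatter, which the earlier compounds could not show, since none of them carried this change. Nothing measured here accounts for that result.

As far as these compounds go, it remains open whether a different group at this place, such as a methoxy group, a nitrile or an amine, would give a step beyond the scatter. Also open, from the compounds shown here alone, is whether the same exchange of fluoro for hydrogen would read alike on the core of compound 1, as one pair cannot settle that.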